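The source may report more compounds than this note shows. Statements on the series, on what has been measured and on what is new or still open speak of the compounds shown alone.

In a functional assay on MCF-10A cells (Homo sapiens) for antiproliferative activity, with a stated time of 48 h (a higher number here means that more compound is needed for the effect, a lower number that less compound is needed), compound 1 `COc1ccc2nc(C)cc(NCc3ccccc3)c2c1` gives 28600 nM, compound 2 `COc1ccc2nc(C)cc(NCc3ccc(N(C)C)cc3)c2c1` gives 20000 nM and compound 3 `CCCOc1ccc2nc(C)cc(NCc3ccc(F)cc3)c2c1` gives 14300 nM. Compound 3 therefore stands within the scatter of both other compounds, so these data do not separate the three.

Compound 4 `CCCCCCCCCCOc1ccc2nc(C)cc(NCc3ccc(F)cc3)c2c1` follows from compound 3 through one change: heptyl in place of hydrogen on a saturated chain carbon, three bonds along the chain from an oxygen on an aromatic ring. The same difference can be read as propyl to decyl. For the measured compounds named here, only one measured step is available, a 1.4-fold lower number from compound 1 to compound 2 (0.16 log units; within the scatter), and it lies within the scatter. That step concerns an aromatic carbon rather than the saturated chain, so it bears on the new change only indirectly. Compound 1 and compound 3 differ in more than one place, and their values show only that they lie within the scatter of each other. Going by the values given here, no measured pair isolates a change in chain length, and the extension is large, so the direction remains uncertain and the range must stay wide.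

Among the compounds with values here, with no measured step pointing either way, no shift beyond the scatter is expected, and the estimated change is a 1.2-fold lower number from compound 3 to compound 4 (0.08 log units; within the scatter). Compound 4 is therefore estimated at 12000 nM, with an expected range from 4000 nM to 36000 nM.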

Compound 4, half-maximal effective concentration: 2000 nM
Estimate against measurement, compound 4: 6.0-fold (0.78 log units) above; the whole stated range lies above it.
By their numbers in this assay, from the lowest: compound 4; then compounds 3, 2 and 1 (each within the scatter of the next).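

In this assay, the step from a propyl to a decyl chain, with heptyl in place of hydrogen on a saturated chain carbon, three bonds along the chain from an oxygen on an aromatic ring, gives a 7.2-fold lower number from compound 3 to compound 4 (0.85 log units; beyond the scatter). This is the first step among the compounds shown to lie beyond the scatter, whereas the only earlier step, on an aromatic carbon, gives a 1.4-fold lower number from compound 1 to compound 2 (0.16 log units; within the scatter) and stays within it. The new step shows that this chain position can alter the number in this assay, which the first three compounds could not show, but no measurement available here accounts for the step.

For the compounds shown here, compounds 3 and 4 give only two chain lengths at this position, so they leave open how the number moves between them, where a hexyl chain would fall, and whether a longer chain such as dodecyl would lower it further or raise it again. They also leave open whether a chain of similar length ending in an amine or a carboxylic acid would give a step of similar size.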